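Benzyl group variation on a shared core: toward compound 4

A few compounds are considered here, and "the series" means these few. Any claim that something is new, unique, unknown or untested is made for them only; others in the source may bear on it.

Three compounds share one core and differ only in the aryl group on a saturated chain carbon bound to a sulfur: compound 1 `Fc1ccc(CSc2nnc(-c3ccc4c(c3)OCCO4)o2)cc1`, compound 2 `Clc1ccccc1CSc1nnc(-c2ccc3c(c2)OCCO3)o1` and compound 3 `Cc1ccc(CSc2nnc(-c3ccc4c(c3)OCCO4)o2)cc1`. In a functional assay on SW 1116 cells (Homo sapiens) for antiproliferative activity, read by MTT assay, with a stated time of 48 h (a lower number here means a stronger inhibitor, a higher number a weaker inhibitor), compound 1 gives 21600 nM, compound 2 gives 29500 nM and compound 3 gives 32500 nM. Compound 3 sits within scatter of both others: a 1.5-fold higher number from compound 1 to compound 3 (0.18 log units; within the scatter) and a 1.1-fold higher number from compound 2 to compound 3 (0.04 log units; within the scatter). Compound 4 `Fc1ccccc1CSc1nnc(-c2ccc3c(c2)OCCO3)o1` differs from compound 3 by 2-fluorophenyl in place of 4-methylphenyl on a saturated chain carbon bound to a sulfur. Bearing on this are the exchange of 2-chlorophenyl for 4-methylphenyl, a 1.1-fold higher number from compound 2 to compound 3 (0.04 log units; within the scatter), the methyl-for-fluoro swap, a 1.5-fold higher number from compound 1 to compound 3 (0.18 log units; within the scatter), and a 1.4-fold higher number from compound 1 to compound 2 (0.14 log units; within the scatter); none left the scatter. The expected step in this assay is therefore a 1.3-fold lower number from compound 3 to compound 4 (0.10 log units; within the scatter), nothing beyond scatter. Compound 4 is estimated at 26000 nM, with a range from 12000 nM to 55000 nM.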

Compound 4, half-maximal inhibitory concentration: 21900 nM
The estimate for compound 4 lay 1.2-fold (0.07 log units) above the measured number, within the range that was stated.
By their numbers in this assay, from the lowest: compounds 1, 4, 2 and 3 (each within the scatter of the next).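

In this assay, 2-fluorophenyl on a saturated chain carbon bound to a sulfur stays within the scatter of all three earlier aryl groups: a 1.5-fold lower number from compound 3 to compound 4 (0.17 log units; within the scatter), a 1.3-fold lower number from compound 2 to compound 4 (0.13 log units; within the scatter) and a 1.0-fold higher number from compound 1 to compound 4 (0.01 log units; within the scatter). The fluoro-for-chloro exchange and the move from 4-fluorophenyl to 2-fluorophenyl therefore add two more steps that do not separate the compounds, so the four aryl groups cannot be told apart at this position. No supporting evidence bears on this result. As far as these compounds go, whether an amine, a carboxylic acid or a longer chain in place of the benzyl group would leave the scatter stays open.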